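The source may hold more compounds than are shown below. What is called first, only, known or untested is meant among the compounds shown, and "the series" means these compounds.

Measured in a functional assay on U-87MG ATCC cells for inhibition, with U-87 MG (Homo sapiens) as the target, read by MTT assay, with a stated time of 48 h; a lower number here means a stronger inhibitor, a higher number a weaker inhibitor:
Compound 1 `Cc1ccc(-c2nc3ccccn3c2Sc2ccccc2)cc1`: > 100000 nM, a limit.
Compound 2 `N#Cc1ccc(-c2nc3ccccn3c2Sc2ccccc2)cc1`: 65500 nM.
Compound 3 `c1ccc(Sc2c(-c3cccs3)nc3ccccn23)cc1`: > 100000 nM, a limit.

Compound 3 stands on a limit and not a number, and the readings so far show (the limit of > 100000 nM in this assay, at which 2 of the 3 values shown sit).

Compound 4 `Clc1ccc(Sc2c(-c3cccs3)nc3ccccn23)cc1` has chloro in place of hydrogen on an aromatic carbon, phenyl to 4-chlorophenyl, para to a large group: chloro in place of hydrogen on an aromatic carbon.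

Going by the values given here, no measured step makes this change. The nearest evidence lies elsewhere on the molecule: an at least 1.5-fold lower number from compound 1 to compound 2 (0.18 log units; that floor lies within the scatter), an at least 1.5-fold higher number from compound 2 to compound 3 (0.18 log units; that floor lies within the scatter) and a step that the two limits leave unreadable from compound 1 to compound 3. None of these gives a size beyond the scatter, so no step beyond the scatter is expected in this assay, and no direction is expected either.

The expected step is a number no higher from compound 3 to compound 4 (the limit leaves the size open).

For compound 4 the estimate is 100000 nM, with an expected range of 40000 nM to 250000 nM.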

Compound 4, half-maximal inhibitory concentration: > 100000 nM
Compound 4: only a limit was reported; the forecaster's own chance of this, stated with the estimate: 55%; the middle value sits exactly at the limit.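

In this assay, going by these compounds alone, compound 3 and compound 4 both stand on limits, so no step between them can be read: the limit of > 100000 nM in this assay, at which 3 of the 4 values shown sit.
The compounds shown leave open what chloro in place of hydrogen does to a value that lies within the readable range of the assay.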